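The compounds below may be only part of what the source reports. "The series", "measured", "known", "first", "only" and "open" are said of these compounds alone.

Measured compounds:
Compound 1 `CN1OC(n2cc3cc(-c4ccccc4)oc3nc2=O)CC1CO` gives > 250000 nM in an ADME assay on BSC-1 cells (Chlorocebus aethiops) for cytotoxicity, read by microscopy, with a stated time of 96 h; a higher number here means that more compound is tolerated, a lower number that less compound is tolerated; this is a limit of the assay, not a number.
Compound 2 `CCCCCc1ccc(-c2cc3cn(C4CC(CO)N(C)O4)c(=O)nc3o2)cc1` gives 6000 nM in this assay.

Compound 2 thus stands as the only number shown; the other value is a limit. The step from compound 2 to compound 3 `COc1ccc(-c2cc3cn(C4CC(CO)N(C)O4)c(=O)nc3o2)cc1` makes one change: methoxy in place of pentyl on an aromatic carbon. Among the measured compounds shown here, only one measured step bears on it: an at least 41-fold lower number from compound 1 to compound 2 (1.61 log units; beyond the scatter), a move from the limit of > 250000 nM in this assay, at which 1 of the 2 values shown sits, to a real number. That step put pentyl on; the present step takes pentyl off again and puts methoxy in its place, so a move back toward the limit seen with compound 1 seems plausible, yet methoxy is not hydrogen, and a limit gives no size for how far the number might climb. The step expected is a 17-fold higher number from compound 2 to compound 3 (1.22 log units; beyond the scatter). Compound 3 is therefore estimated at 100000 nM, ranging from 20000 nM to 250000 nM, with a real chance that only a limit is reported.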

Compound 3, minimum cytotoxic concentration: 62000 nM
The estimate for compound 3 lay 1.6-fold (0.21 log units) above the measured number, and the stated range covers the measured number.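

Replacing pentyl with methoxy at this position gives a 10-fold higher number from compound 2 to compound 3 (1.01 log units; beyond the scatter) in this assay, so a group placed here need not bring the number down as far as it stands for compound 2. Methoxy still does not match the unsubstituted compound, since methoxy in place of hydrogen gives an at least 4.0-fold lower number from compound 1 to compound 3 (0.60 log units; beyond the scatter). The true size of that step stays open-ended because compound 1 gives a limit of the assay, not a number: the limit of > 250000 nM in this assay, at which 1 of the 3 values shown sits.

Pentyl and methoxy differ both in the length of the group and in the oxygen that methoxy carries, and the compounds shown cannot separate these two differences. Going by these compounds, how a propyl chain, an ethoxy group, an amine or a carboxylic acid would behave at this position remains open.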